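Chain extension on the hydroxy-bearing core

This account rests on a few compounds, and the source may have more. Where it says the series, first, only, none or still open, it means among the compounds named here.

Compound 1 `CC=C(/C=C/c1ccc(OC)c(N)c1)c1cc(OC)c(OC)c(OC)c1` and compound 2 `CCC=C(/C=C/c1ccc(OC)c(N)c1)c1cc(OC)c(OC)c(OC)c1` share one core; compound 3 `CCC=C(/C(C)=C/c1ccc(OC)c(O)c1)c1cc(OC)c(OC)c(OC)c1` and compound 4 `CCCC=C(/C(C)=C/c1ccc(OC)c(O)c1)c1cc(OC)c(OC)c(OC)c1` share another, and the difference between the two cores is not broken down here. In a functional assay on PC-3 cells (Homo sapiens) for antiproliferative activity, read by MTT assay, with a stated time of 48 h (a higher number here means a weaker inhibitor, a lower number a stronger inhibitor), compound 1 gives 319 nM and compound 2 gives 285 nM. The change between them, (methyl in place of hydrogen on a saturated chain carbon bound to a double-bonded chain carbon), made a step of a 1.1-fold lower number from compound 1 to compound 2 (0.05 log units; within the scatter). Compound 3 gives 4230 nM in this assay, the highest of the three numbers. Compound 4 carries the same kind of change, (methyl in place of hydrogen on a saturated chain carbon, two bonds along the chain from a double-bonded chain carbon). The two places are not identical: in compound 2 the entering methyl sits on a saturated chain carbon bound to a double-bonded chain carbon, whereas in compound 4 it sits on a saturated chain carbon two bonds along the chain from a double-bonded chain carbon. Going by the values given here, the step from compound 3 to compound 4 is expected to be a 1.1-fold higher number from compound 3 to compound 4 (0.03 log units; within the scatter), resting on the one measured step of a 1.1-fold lower number from compound 1 to compound 2 (0.05 log units; within the scatter); the range is kept wide since that step sits on a different core and a different place. Compound 4 is expected to give 4500 nM in this assay, between 2000 nM and 10000 nM.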

Compound 4, half-maximal inhibitory concentration: 4510 nM
Compound 4: middle estimate off by 1.0-fold (0.00 log units), on the low side; low and high end bracket the measured number.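

In this assay, methyl in place of hydrogen on a saturated chain carbon, two bonds along the chain from a double-bonded chain carbon, gives a 1.1-fold higher number from compound 3 to compound 4 (0.03 log units; within the scatter), so this change does not separate the two compounds in this read-out. Set beside the earlier step, the change carries from one core to the other with no difference in size that can be told from the scatter: the same change on two cores in this assay, a 1.1-fold lower number (0.05 log units; within the scatter) from compound 1 to compound 2 and a 1.1-fold higher number (0.03 log units; within the scatter) from compound 3 to compound 4, 1.2-fold (0.08 log units) apart, within the scatter of two such steps. Going by these compounds alone, this rests on only two steps, in a single assay and at places on the chain that are not identical, so it shows agreement for these two pairs, not a rule for the series, and it says nothing about the difference between the two cores.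

Still open, from the compounds shown here alone, is whether a longer chain, such as butyl, would stay just as silent on either core. Also open, going by these compounds, is whether a carboxylic acid or a hydroxyl at the end of the chain, in place of the entering methyl, would leave the number as undisturbed.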